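The source may report more compounds than this note shows. Statements on the series, on what has been measured and on what is new or still open speak of the compounds shown alone.

In a physicochemical assay for lipophilicity, at pH 7.4 (on this read-out higher numbers stand for higher lipophilicity and lower numbers for lower lipophilicity), compound 1 `CCOc1ccc2c(c1)C(c1cn[nH]c1)=CN(C)C(=O)[C@@H]2C` gives 3.4 and compound 2 `CCOc1ccc2c(c1)C(c1cc[nH]n1)=CN(C)C(=O)C2C` gives 3.8, while compound 3 `C[C@H]1C(=O)N(C)C=C(c2cn[nH]c2)c2cc([C@H](O)CO)ccc21` gives 0.8, the lowest of the three numbers and clearly apart from the other two. The next molecule, compound 4 `C[C@H]1C(=O)N(C)C=C(c2cn[nH]c2)c2cc([C@@H](O)CO)ccc21`, has not yet been measured. Its relation to compound 3 is simple to state: the two compounds have the same atoms and bonds and differ only in configuration as drawn: 1 of 2 stereo elements differ; a stereocentre at a saturated chain carbon is drawn S in compound 3 and R in compound 4. A stereocentre is a carbon whose groups can be arranged in space in two ways, and here only that arrangement is reversed, while the other stereo element stays as drawn.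

Within the data shown here, the only measured step that bears on this part of the molecule is a number 2.60 log units lower from compound 1 to compound 3 (beyond the scatter), with 1,2-dihydroxyethyl in place of ethoxy on an aromatic carbon. That step was large, but it swapped one group for another. Among the measured compounds shown here, no measured pair here differs in configuration alone, so it gives no size for the present change. With the same atoms and bonds on both sides, no step beyond the scatter is expected in this assay, in either direction, although the data hold no direct test of this. The estimated step is no change at the digits printed from compound 3 to compound 4 (within the scatter), which would amount to no real change. For compound 4 the expected value is 0.8, with an estimated range from 0.5 to 1.1.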

Compound 4, distribution coefficient: 0.9
The estimate for compound 4 lay 0.10 log units below the measured number, within the range that was stated.
By their numbers in this assay, from the lowest: compounds 3 and 4 (each within the scatter of the next); then compound 1; then compound 2.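

In this assay, reversing the drawn configuration at the saturated chain carbon gives a number 0.10 log units higher from compound 3 to compound 4 (within the scatter), which puts a first measured size on a change of configuration alone at this position: on these numbers, the two arrangements cannot be told apart. The comparison is a clean one for a single reason: the fact that compounds 3 and 4 differ only in the configuration as drawn. The large effect of 1,2-dihydroxyethyl in place of ethoxy also turns out not to belong to one drawn configuration, since a number 2.60 log units lower from compound 1 to compound 3 (beyond the scatter) is matched by a number 2.50 log units lower from compound 1 to compound 4 (beyond the scatter), both beyond the scatter.

What the compounds shown leave open is whether configuration would stay without a measurable effect on this read-out with another group at this place, such as an amine, a carboxylic acid or a longer chain carrying a hydroxyl group. They also leave open whether the two arrangements of the 1,2-dihydroxyethyl group would stay this close in any other kind of assay, because a single physicochemical read-out says nothing about the rest of their behaviour.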